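Amides on the shared core: inactive so far

The source may hold more compounds than are shown below. What is called first, only, known or untested is meant among the compounds shown, and "the series" means these compounds.

The series keeps the core of compound 1 `O=C(Nc1ccc(Cl)c(-c2nnc3c(Cl)cccn23)c1)c1cccnc1` and varies the group on the carbonyl carbon. In a functional assay on U-251 cells (Homo sapiens) for antiproliferative activity, read by MTT assay, with a stated time of 72 h (a lower number here means a stronger inhibitor, a higher number a weaker inhibitor), compound 1 gives only a limit of the assay, > 100000 nM. Compound 2 `Cc1cc(Cl)ccc1C(=O)Nc1ccc(Cl)c(-c2nnc3c(Cl)cccn23)c1`, with 4-chloro-2-methylphenyl in place of pyridin-3-yl, likewise reaches only a limit, > 100000 nM. Compound 3 `O=C(Nc1ccc(Cl)c(-c2nnc3c(Cl)cccn23)c1)c1ccc(Cl)cc1Cl`, carrying 2,4-dichlorophenyl, again sits at a limit, > 100000 nM. The steps a step that the two limits leave unreadable from compound 1 to compound 2, a step that the two limits leave unreadable from compound 1 to compound 3 and a step that the two limits leave unreadable from compound 2 to compound 3 therefore carry no readable size; all that is seen is the limit of > 100000 nM in this assay, at which 3 of the 3 values shown sit.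

Compound 3 thus stands nowhere distinguishable from its two neighbours on the numbers shown. The next compound, compound 4 `O=C(Nc1ccc(Cl)c(-c2nnc3c(Cl)cccn23)c1)c1ccccc1`, differs from compound 3 by phenyl in place of 2,4-dichlorophenyl on a carbonyl carbon. Among the compounds with values here, no measured step bears on this change in a readable way, since every step so far is hidden behind the same limit. Compound 4 is therefore expected to lie at or near that limit as well, with a step that the limit leaves unreadable from compound 3 to compound 4 as the expected change. The estimate for compound 4 in this assay is 150000 nM, with a range from 30000 nM to 1000000 nM, and a high chance that only a limit is reported.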

Compound 4, half-maximal inhibitory concentration: 73500 nM
For compound 4 the middle estimate is 2.0-fold (0.31 log units) above the measured one; the measured number falls inside the stated range.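

In this assay, within the data shown here, compound 4, with phenyl on the carbonyl carbon, is the only member of the series that gives a number and not a limit, so this position now has one readable point. Against the three substituted or nitrogen-containing groups, the change reads as an at least 1.3-fold lower number from compound 3 to compound 4 (0.13 log units; that floor lies within the scatter), as an at least 1.3-fold lower number from compound 2 to compound 4 (0.13 log units; that floor lies within the scatter) and as an at least 1.3-fold lower number from compound 1 to compound 4 (0.13 log units; that floor lies within the scatter); each of these is a floor only, so it sets no true size for the step and does not separate phenyl from the other groups beyond the scatter. The series as shown therefore has a single number, and the rest of it stays at one limit: the limit of > 100000 nM in this assay, at which 3 of the 4 values shown sit.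

As far as these compounds go, the steps among compound 1, compound 2 and compound 3 still cannot be read, so it remains open whether 2,4-dichlorophenyl, 4-chloro-2-methylphenyl and pyridin-3-yl differ from each other at all. Also open, from the compounds shown here alone, is how this position responds to an amine, a carboxylic acid or a longer chain on the carbonyl carbon in place of phenyl, and whether any such group gives a number clearly lower than that of compound 4.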